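The source may hold more compounds than are shown below. What is called first, only, known or untested is meant among the compounds shown, and "the series" means these compounds.

Compound 1 `CC[C@H](C)[C@H](N)CN(C(=O)[C@@H]1C[C@H]1C1CCCCC1)c1ccc(-c2ccccc2)cc1`: in a functional assay for agonist activity at G protein-coupled receptor 88 (Homo sapiens), read by HTRF and cAMP accumulation (on this read-out higher numbers stand for an effect only at larger amounts of compound and lower numbers for an effect already at smaller amounts), compound 1 gives only a limit, > 25000 nM.
Compound 2 `CC[C@H](C)[C@H](N)CN(C(=O)[C@@H]1C[C@H]1c1cc(F)ccc1F)c1ccc(-c2ccccc2)cc1`: in this assay compound 2 gives 770 nM.

For the measured compounds named here, compound 2 thus holds the only number in the set; the other value is a limit (the limit of > 25000 nM in this assay, at which 1 of the 2 values shown sits). Going by the values given here, the single measured step, an at least 32-fold lower number from compound 1 to compound 2 (1.51 log units; beyond the scatter), concerns cyclohexyl against 2,5-difluorophenyl and says nothing about where fluorine sits on that ring. Compound 3 `CC[C@H](C)[C@H](N)CN(C(=O)[C@@H]1C[C@H]1c1c(F)cccc1F)c1ccc(-c2ccccc2)cc1` differs from compound 2 by 2,6-difluorophenyl in place of 2,5-difluorophenyl on a saturated ring carbon. Among the compounds with values here, no measured step bears on this change, so no step beyond the scatter is expected in this assay in either direction, though the uncertainty is wide. Compound 3 is estimated at 1000 nM, expected between 250 nM and 6000 nM, which corresponds to an expected step of a 1.3-fold higher number from compound 2 to compound 3 (0.11 log units; within the scatter).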

Compound 3, half-maximal effective concentration: 11000 nM
Compound 3: middle estimate off by 11-fold (1.04 log units), on the low side; measured number outside the range, above it.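

In this assay this position responds to where fluorine sits and not only to the presence of a difluorophenyl: with the same atoms, 2,6-difluorophenyl in place of 2,5-difluorophenyl gives a 14-fold higher number from compound 2 to compound 3 (1.15 log units; beyond the scatter) and loses most of what the 2,5-difluorophenyl group gained. Against cyclohexyl, 2,6-difluorophenyl still gives an at least 2.2-fold lower number from compound 1 to compound 3 (0.35 log units; beyond the scatter) on the same read-out. Compound 1 holds only a limit, so that step has no upper end: the limit of > 25000 nM in this assay, at which 1 of the 3 values shown sits.

Open, as far as these compounds go, is how unsubstituted phenyl, a single fluorine or 2,5-dichlorophenyl would read at this position. Also open, from the compounds shown here alone, is whether a methoxy group or a nitrile would be tolerated there.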